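Working notes: chloro substitution on compound 3

The compounds below may be only part of what the source reports. "The series", "measured", "known", "first", "only" and "open" are said of these compounds alone.

Measured in an ADME assay on Vero 76 cells (Chlorocebus sabaeus) for cytotoxicity, read by neutral red uptake; a higher number here means that more compound is tolerated, a lower number that less compound is tolerated:
- compound 1, `CC(C)[C@@H](Nc1nc(Cl)nc2c1ncn2[C@H]1[C@H](O)[C@H](O)[C@]2(CCl)C[C@H]12)C1CC1`, 27000 nM
- compound 2, `NC(=O)c1ncn([C@H]2[C@H](O)[C@H](O)[C@]3(CO)C[C@H]23)n1`, > 50000 nM
- compound 3, `OC[C@H]1O[C@@H](n2cnc3c(NC(C4CCC4)C4CCC4)ncnc32)[C@H](O)[C@@H]1O`, > 100000 nM

Compound 3 sits only at a limit of this assay, (the limit of > 100000 nM in this assay, at which 1 of the 3 values shown sits), so no number fixes its place. Compound 2 likewise sits only at a limit, (the limit of > 50000 nM in this assay, at which 1 of the 3 values shown sits). Within the data shown here, compound 1 is the one compound that gives a number in this assay, 27000 nM. Compound 4, `OC[C@H]1O[C@@H](n2cnc3c(NC(C4CCC4)C4CCC4)nc(Cl)nc32)[C@H](O)[C@@H]1O`, differs from compound 3 by chloro in place of hydrogen on an aromatic carbon. Among the measured compounds shown here, no measured pair isolates this change; compound 1 also carries a chloro on its core. A moderate fall in tolerated concentration is expected, and the step of an at least 1.6-fold lower number from compound 3 to compound 4 (0.22 log units; that floor lies within the scatter) is the estimate of it. Compound 4 is expected at 60000 nM, with a likely range from 20000 nM to 150000 nM.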

Compound 4, half-maximal cytotoxic concentration: 27000 nM
Estimate against measurement, compound 4: 2.2-fold (0.35 log units) above, and the stated range covers the measured number.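

In this assay, among these compounds, chloro in place of hydrogen on an aromatic carbon between two ring nitrogen atoms gives an at least 3.7-fold lower number from compound 3 to compound 4 (0.56 log units; beyond the scatter), and this is the first pair to isolate the change at this position. The value of compound 3 is a limit, and the step is therefore a floor, with its full size unknown: the limit of > 100000 nM in this assay, at which 1 of the 4 values shown sits.

Going by these compounds, whether a fluoro, an amine or a methoxy group at this position would lower the tolerated concentration to the same degree remains open. Also open, on these data alone, is whether chloro gives a similar step on the core of compound 2.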